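Swapping the phenylsulfanyl side chain for a piperidine

A few compounds are considered here, and "the series" means these few. Any claim that something is new, unique, unknown or untested is made for them only; others in the source may bear on it.

In a functional assay on the whole organism (B cells) with Mus musculus as the target (on this read-out higher numbers stand for larger maximal responses and lower numbers for smaller maximal responses), compound 1 `CCCn1c(=O)n(C2CCC(COC(C)=O)O2)c2nc(NC(C)=O)nc(O)c21` gives 100%. Compound 2 `Nc1nc(O)c2c(n1)n(C1OC(CO)[C@@H](O)[C@H]1O)c(=O)n2CC(O)CSc1ccccc1` gives 12% in this assay, the second highest of the three numbers; it lies within the usual scatter of compound 3 `C=CCn1c(=S)n(C2OC(CO)[C@@H](O)C(O)[C@H]2O)c2nc(N)nc(O)c21`, which gives 5%, and far beyond the scatter below compound 1. Compound 4 `Nc1nc(O)c2c(n1)n(C1OC(CO)[C@@H](O)[C@H]1O)c(=O)n2CCN1CCCCC1` differs from compound 2 in one place: (piperidin-1-yl)methyl in place of 1-hydroxy-2-(phenylsulfanyl)ethyl on a saturated chain carbon bound to an aromatic nitrogen. Among the compounds with values here, no pair of measured compounds isolates this change, so the expectation rests on compound 2 alone. A step from compound 2 to compound 4 that is expected to stay within the scatter, or at most slightly upward, is a number 3 percentage points higher from compound 2 to compound 4 (within the scatter). Compound 4 is therefore estimated to give 15% in this assay, in the range 3% to 40%.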

Compound 4, largest response reached (reported as maximal response), in percent of the reference or control that the assay uses: 0%
Compound 4: the middle estimate sits 15 percentage points above what was measured, and the stated range ends above it.
By their numbers in this assay, from the lowest: compounds 4, 3 and 2 (each within the scatter of the next, the first and the last beyond it); then compound 1.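

In this assay the replacement of 1-hydroxy-2-(phenylsulfanyl)ethyl by (piperidin-1-yl)methyl is a number 12 percentage points lower from compound 2 to compound 4 (beyond the scatter) and shows that the response depends on the group at this saturated chain carbon bound to an aromatic nitrogen. Within the data shown here, the earlier compounds differed in more than one place, so this is the first change here that can be read on its own. Nothing measured here bears on why the response falls.

The hydroxy group, the sulfur and the aromatic ring leave together, and the compounds shown do not separate them. They also leave open how a side chain ending in a primary amine or a carboxylic acid would behave.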